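Replacing the (vinylsulfonyl)amino group of compound 3

The compounds below may be only part of what the source reports. "The series", "measured", "known", "first", "only" and "open" are said of these compounds alone.

In a functional assay on K562 cells (Homo sapiens) for inhibition, read by luminescence, with a stated time of 72 h, tested at 5 uM (a higher number here means more inhibition of growth at the concentration tested, a lower number less inhibition of growth), compound 1 (`C=CS(=O)(=O)NC/C=C/c1cc(OC)cc(O)c1C(=O)OC(C)C`) gives 36.2%, compound 2 (`C=CS(=O)(=O)NC/C=C/c1cc(OC)cc(O)c1C(=O)OCc1ccc(Br)cc1`) gives 38.4% and compound 3 (`C=CS(=O)(=O)NC/C=C/c1cc(OC)cc(O)c1C(=O)OCC(C)c1ccccc1`) gives 16.7%, the lowest of the three numbers. Compound 4 (`COc1cc(O)c(C(=O)OCC(C)c2ccccc2)c(/C=C/CN2C(=O)C=CC2=O)c1`) differs from compound 3 by one change: a group of 7 heavy atoms (4 carbon, 1 nitrogen, 2 oxygen; one five-membered non-aromatic ring with 1 hetero atom) in place of a group of 6 heavy atoms (2 carbon, 1 nitrogen, 2 oxygen, 1 sulfur; no ring), on a saturated chain carbon bound to a double-bonded chain carbon.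

The measured steps all concern the group on an oxygen next to a carbonyl group. One runs a number 2.2 percentage points higher from compound 1 to compound 2 (within the scatter), another a number 19.5 percentage points lower from compound 1 to compound 3 (beyond the scatter) and the third a number 21.7 percentage points lower from compound 2 to compound 3 (beyond the scatter). None of them alters the (vinylsulfonyl)amino group, so they bear on the new change only indirectly. They show modest movement at most, and the series holds no direct measure for this replacement. A small rise in this assay is therefore expected, with no step beyond the scatter, though with low confidence. The expected step is a number 8.3 percentage points higher from compound 3 to compound 4 (within the scatter). For compound 4 the estimated value is 25%, with an expected range of 5% to 60%.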

Compound 4, percent growth inhibition at one concentration: 74.9%
Compound 4: middle estimate off by 49.9 percentage points, on the low side; measured number above the stated range.
By their numbers in this assay, from the lowest: compound 3; then compounds 1 and 2 (each within the scatter of the next); then compound 4.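

In this assay, among these compounds, the position on a saturated chain carbon bound to a double-bonded chain carbon responds far more strongly than the group varied among the earlier compounds: the five-membered non-aromatic ring group in place of (vinylsulfonyl)amino gives a step (a number 58.2 percentage points higher from compound 3 to compound 4 (beyond the scatter)) well above the earlier steps (a number 19.5 percentage points lower from compound 1 to compound 3 (beyond the scatter) and a number 21.7 percentage points lower from compound 2 to compound 3 (beyond the scatter)). Among the compounds shown here, the earlier compounds all carry (vinylsulfonyl)amino, so this is the first sign that the group at this position can outweigh the differences seen among them. The change also removes the hydrogen-bond donor of (vinylsulfonyl)amino, but no measurement here explains the rise.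

On these data alone, it remains open whether the ring, its double bond or the missing donor matters, which an acrylamide or the saturated succinimide would test. As far as these compounds go, it is equally open whether the gain carries over to the isopropyl and 4-bromobenzyl compounds.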